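The compounds below may be only part of what the source reports. "The series", "measured", "known", "first", "only" and "open" are said of these compounds alone.

Measured compounds:
compound 1, `COc1ccc(N2C(=O)COc3ccc(-c4cnc5ccccc5c4)cc32)cc1`: > 40000 nM
compound 2, `O=C1COc2ccc(-c3ccc(O)cc3)cc2N1`: > 40000 nM

The measurements come from a functional assay on A549 cells (Homo sapiens) for antiproliferative activity, read by MTT assay, with a stated time of 72 h; on this read-out higher numbers stand for weaker inhibition and lower numbers for stronger inhibition. Compound 1 does not give a number in this assay; it gives only a limit, > 40000 nM. Compound 2 is a second structure whose result in this assay is also a limit, > 40000 nM. So both measured compounds sit at the limit of > 40000 nM in this assay, at which 2 of the 2 values shown sit, and no step between measured compounds that differ in a single place is available. Where compound 1 stands can only be said as this: it is at the limit, together with the other measured compound.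

Compound 3, `O=C1COc2ccc(-c3cnc4ccccc4c3)cc2N1c1ccc(Cl)cc1`, has not yet been measured in this assay. It differs from compound 1 in one place: chloro in place of methoxy on an aromatic carbon. With nothing measured on either side of this change, no pull in either direction can be read from the data, and the change is expected to give no step beyond the usual scatter. Compound 3 is therefore expected to give about 40000 nM, with a range from 8000 nM to 150000 nM. That estimate means a step of a number no higher from compound 1 to compound 3 (the limit leaves the size open), which is expected to stay within the scatter.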

Compound 3, half-maximal inhibitory concentration: > 40000 nM
Compound 3: a limit, no number; the forecaster's own chance of this, stated with the estimate: 70%; the middle value lies on the limit itself.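

No step can be read between compound 1 and compound 3, because both results are limits and not numbers: the limit of > 40000 nM in this assay, at which 3 of the 3 values shown sit. The compounds shown leave open how chloro and methoxy compare on this ring, and whether any compound of this kind gives an actual number in this assay.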